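Swapping the triazole of compound 1 for a methylimidazole

This account rests on a few compounds, and the source may have more. Where it says the series, first, only, none or still open, it means among the compounds named here.

For the measured compounds named here, compound 1, with the structure `c1ccc(-c2nc[nH]n2)c(NCC2=NCCN2)c1`, is the only member of this small set that gives a numerical result. In an in vitro functional assay on cells (Fibroblast) for agonist activity at Alpha-1B adrenergic receptor (Homo sapiens) (on this read-out lower numbers stand for an effect already at smaller amounts and higher numbers for an effect only at larger amounts of compound), compound 1 gives 5.01 nM. Two related compounds, compound 2 with the structure `CC(C)n1nccc1-c1ccccc1NCC1=NCCN1` and compound 3 with the structure `CCn1cc(-c2ccccc2NCC2=NCCN2)cn1`, share the same core but carry different five-membered rings. For compound 2 this assay reports only a limit, < 100000 nM. For compound 3 the result is likewise a limit, < 100000 nM. So compound 1 stands alone with a measured number, while the remaining values sit at the limit of < 100000 nM in this assay, at which 2 of the 3 values shown sit.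

Compound 4, with the structure `Cn1ccnc1-c1ccccc1NCC1=NCCN1`, is not yet measured. It differs from compound 1 in one place: 1-methyl-1H-imidazol-2-yl in place of 1H-1,2,4-triazol-3-yl on an aromatic carbon. The triazole of compound 1 brings one hydrogen-bond donor; the methylimidazole of compound 4 brings none, as the count above shows. Going by the values given here, no measured pair tells how this exact change behaves, but the weight of the set lies with compounds that return no number, because of the limit of < 100000 nM in this assay, at which 2 of the 3 values shown sit. The expected step is a 400-fold higher number from compound 1 to compound 4 (2.60 log units; beyond the scatter), toward weaker potency, well beyond the usual scatter. Compound 4 is therefore estimated to give 2000 nM in this assay, within a range from 100 nM to 50000 nM.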

Compound 4, half-maximal effective concentration: 39.8 nM
Compound 4: middle estimate off by 50-fold (1.70 log units), on the high side; measured number below the stated range.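

In this assay, placing 1-methyl-1H-imidazol-2-yl in the spot held by 1H-1,2,4-triazol-3-yl gives a 7.9-fold higher number from compound 1 to compound 4 (0.90 log units; beyond the scatter), which is a real but modest loss, and the result is still a measured number rather than a limit. At this aromatic carbon, then, a five-membered aromatic ring with 0 hydrogen-bond donors can still produce a measurable effect, so the single hydrogen-bond donor of the triazole is not needed for one, although the number does get higher without it. Nothing measured in this set explains the size of this step.

This one change alters several things together: the ring loses its donor, carbon replaces one of the ring nitrogens, and a methyl group appears, so the compounds shown cannot separate these contributions, and an imidazole without the methyl group would be a natural comparison. Also open, on these data alone, is how this position responds to groups of a quite different kind, such as a simple amine or a carboxylic acid, or to a longer chain in place of the methyl group on the imidazole.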